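The compounds below may be only part of what the source reports. "The series", "measured", "known", "first", "only" and "open" are said of these compounds alone.

Among the compounds with values here, compound 1 `ClCc1ccccc1Cn1cnc2ncnc(Cl)c21` stands at the higher of the two numbers measured so far: in a functional assay on NCI-H522 cells (Homo sapiens) for cytotoxicity, read by sulforhodamine B assay, with a stated time of 48 h (a higher number here means a weaker inhibitor of growth, a lower number a stronger inhibitor of growth), compound 1 gives 75900 nM, while compound 2 `Nc1nc(Cl)c2ncn(Cc3cccc(CCl)c3)c2n1` gives 13500 nM in this assay, a gap beyond the usual scatter. Compound 3 `ClCc1ccccc1Cn1cnc2nc(Cl)nc(Cl)c21` differs from compound 1 in one place: chloro in place of hydrogen on an aromatic carbon. Within the data shown here, no measured pair shows what this change does here, so the step from compound 1 to compound 3 is only an expectation, estimated at a 1.9-fold lower number from compound 1 to compound 3 (0.28 log units; within the scatter), a small move toward stronger growth inhibition rather than a large shift. Compound 3 is thus expected to give 40000 nM in this assay, within a range from 10000 nM to 150000 nM.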

Compound 3, concentration for total growth inhibition: 7240 nM
Estimate against measurement, compound 3: 5.5-fold (0.74 log units) above; the measured number lies below the stated range.
By their numbers in this assay, from the lowest: compounds 3 and 2 (each within the scatter of the next); then compound 1.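

Chloro in place of hydrogen on the aromatic carbon between two ring nitrogen atoms gives a 10-fold lower number from compound 1 to compound 3 (1.02 log units; beyond the scatter) in this assay. Within the data shown here, this is the first single-change pair, and it shows that this position can strongly affect growth inhibition, even though the change adds only one heavy atom. Nothing available explains this step. On these data alone, whether the gain is specific to chloro remains open, since a fluoro or methoxy group at the same carbon could give a smaller, similar or larger step. This single pair also cannot show whether chloro would have the same effect on another core.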